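A Furan Replaces Naphthalene on the Shared Core

The source may report more compounds than this note shows. Statements on the series, on what has been measured and on what is new or still open speak of the compounds shown alone.

In a functional assay on Ehrlich cells (Mus musculus) for cytotoxicity, tested at 25 ug/mL (a higher number here means a stronger effect of the compound at the concentration tested, a lower number a weaker effect), compound 1 `COc1cc(N2C(N)=C(C#N)C(c3ccc([N+](=O)[O-])cc3)C3=C2CC(C)(C)CC3=O)cc(OC)c1OC` gives 50%.
Compound 2 `COc1ccc(C2C(C#N)=C(N)N(c3cc(OC)c(OC)c(OC)c3)C3=C2C(=O)CC(C)(C)C3)cc1` gives 1%.
Compound 3 `COc1cc(N2C(N)=C(C#N)C(c3c(OC)ccc4ccccc34)C3=C2CC(C)(C)CC3=O)cc(OC)c1OC` gives 5%.

Compound 3 stands second highest of the three numbers, within the scatter of compound 2 but far from compound 1, as a number 45 percentage points lower from compound 1 to compound 3 (beyond the scatter) shows. Compound 4 `COc1cc(N2C(N)=C(C#N)C(c3ccc(C)o3)C3=C2CC(C)(C)CC3=O)cc(OC)c1OC` differs from compound 3 in one place: 5-methylfuran-2-yl in place of 2-methoxynaphthalen-1-yl on a saturated ring carbon. Among the compounds with values here, two measured steps concern this same saturated ring carbon. The exchange of the nitro-bearing group gave a number 45 percentage points lower from compound 1 to compound 3 (beyond the scatter), a large fall, whereas a number 4 percentage points higher from compound 2 to compound 3 (within the scatter) stayed within the scatter. Both compounds without a nitro group sit low, and compound 4 also lacks one, so a step within the scatter is expected, a number 3 percentage points higher from compound 3 to compound 4 (within the scatter). Compound 4 is therefore estimated at 8%, between 0% and 30%.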

Compound 4, a percentage reported as activity, at one concentration (the size of the read-out at that concentration, not a potency): 31%
The estimate for compound 4 lay 23 percentage points below the measured number; measured number above the stated range.
By their numbers in this assay, from the lowest: compounds 2 and 3 (each within the scatter of the next); then compound 4; then compound 1.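

At this saturated ring carbon, a clear effect in this assay does not need a nitro group, as a number 26 percentage points higher from compound 3 to compound 4 (beyond the scatter) and a number 30 percentage points higher from compound 2 to compound 4 (beyond the scatter) show for 5-methylfuran-2-yl. The furan still falls short of the 4-nitrophenyl group, with a number 19 percentage points lower from compound 1 to compound 4 (beyond the scatter) marking a modest gap. No measurement at hand explains why the furan stands above the two methoxy-bearing groups.

As far as these compounds go, whether the methyl on the furan contributes remains open. So does what a plain furan-2-yl, a thiophene ring or a 5-nitrofuran-2-yl group would give at this carbon.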